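A Second Chloro on the Chlorophenyl Group of Compound 1

The compounds below may be only part of what the source reports. "The series", "measured", "known", "first", "only" and "open" are said of these compounds alone.

Compound 1 `CC(=O)N[C@H]1[C@H]([C@@H](O)[C@H](O)CNC(=O)c2ccc(Cl)cc2)O[C@@](OCc2ccccc2)(C(=O)O)C[C@@H]1O` has the highest number of the three compounds tested in an in vitro assay on cells for binding affinity to myelin-associated glycoprotein (Mus musculus), read by surface plasmon resonance (on this read-out higher numbers stand for weaker binding and lower numbers for tighter binding), where compound 1 gives 17000 nM. Compound 2 `CC(=O)N[C@H]1[C@H]([C@@H](O)[C@H](O)CNC(=O)c2ccc(Cl)cc2)O[C@@](OCc2c(F)c(F)c(F)c(F)c2F)(C(=O)O)C[C@@H]1O` gives 6100 nM, and compound 3 `CC(=O)N[C@H]1[C@H]([C@@H](O)[C@H](O)CNC(=O)c2ccc(Cl)cc2)O[C@@](OCc2ccc3ccccc3c2)(C(=O)O)C[C@@H]1O` gives 11600 nM. All measured steps change only the phenyl bound through a saturated chain carbon to an oxygen: a 2.8-fold lower number from compound 1 to compound 2 (0.45 log units; beyond the scatter), a 1.5-fold lower number from compound 1 to compound 3 (0.17 log units; within the scatter), and a 1.9-fold higher number from compound 2 to compound 3 (0.28 log units; within the scatter). For the measured compounds named here, compound 4 `CC(=O)N[C@H]1[C@H]([C@@H](O)[C@H](O)CNC(=O)c2ccc(Cl)c(Cl)c2)O[C@@](OCc2ccccc2)(C(=O)O)C[C@@H]1O` instead differs from compound 1 by chloro in place of hydrogen on an aromatic carbon, at the other end of the molecule, so none of the measured steps bears on this change. Without a guiding step, compound 4 is expected to stay close to compound 1, with a 1.4-fold lower number from compound 1 to compound 4 (0.15 log units; within the scatter). The estimate for compound 4 is therefore 12000 nM, within a range from 5000 nM to 30000 nM.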

Compound 4, dissociation constant: 19200 nM
The estimate for compound 4 lay 1.6-fold (0.20 log units) below the measured number; low and high end bracket the measured number.
By their numbers in this assay, from the lowest: compounds 2, 3, 1 and 4 (each within the scatter of the next, the first and the last beyond it).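

For the compounds shown here, until now every step concerned the phenyl group at the other end of the molecule; here, in this assay, the move from 4-chlorophenyl to 3,4-dichlorophenyl gives a 1.1-fold higher number from compound 1 to compound 4 (0.05 log units; within the scatter) and is the first look at this end. A chloro on this aromatic carbon, ortho to the existing chloro group, thus leaves the two numbers within the scatter of each other. Nothing available accounts for this result.

From the compounds shown here alone, whether a smaller fluoro or a hydroxyl group on the same carbon would also stay within the scatter remains open. So does whether the second chloro would behave alike on compound 2, which carries the 2,3,4,5,6-pentafluorophenyl group.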